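This account rests on a few compounds, and the source may have more. Where it says the series, first, only, none or still open, it means among the compounds named here.

In a functional assay on HEp-2 cells (Homo sapiens) for inhibition, read by sulforhodamine B assay, with a stated time of 72 h (on this read-out lower numbers stand for stronger inhibition and higher numbers for weaker inhibition), compound 1 `C[C@H](OC(=O)/C=C\c1ccc(O)cc1)[C@@H]1CC[C@H]([C@H](O)[C@H]2CC=CC(=O)O2)O1` gives 7700 nM. Compound 2 `C[C@H](OC(=O)/C=C/c1ccc(O)cc1)[C@@H]1CC[C@H]([C@H](O)[C@H]2CC=CC(=O)O2)O1` reaches only a limit, > 10000 nM. Compound 3 `C[C@H](OC(=O)/C=C/c1ccc(O)c(O)c1)[C@@H]1CC[C@H]([C@H](O)[C@H]2CC=CC(=O)O2)O1` differs from compound 2 by hydroxy in place of hydrogen on an aromatic carbon, with hydroxy in place of hydrogen on an aromatic carbon, 4-hydroxyphenyl to 3,4-dihydroxyphenyl. For the measured compounds named here, the one measured step is an at least 1.2-fold higher number from compound 1 to compound 2 (0.11 log units; that floor lies within the scatter), and it bears only on (the fact that compounds 1 and 2 differ only in the configuration as drawn), so it sets no size for this change. In this assay the expected change is an at least 1.2-fold lower number from compound 2 to compound 3 (0.09 log units; that floor lies within the scatter), with nothing expected beyond the scatter. The estimate for compound 3 is 8000 nM, with an expected range of 2000 nM to 20000 nM.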

Compound 3, half-maximal inhibitory concentration: 9400 nM
For compound 3 the middle estimate is 1.2-fold (0.07 log units) below the measured one, within the range that was stated.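

In this assay, hydroxy in place of hydrogen on the aromatic carbon ortho to a hydroxy group, 4-hydroxyphenyl to 3,4-dihydroxyphenyl, gives an at least 1.0-fold lower number from compound 2 to compound 3 (0.02 log units; that floor lies within the scatter). Compound 2 is recorded only as a limit, > 10000 nM. The added hydroxy therefore shows no change beyond the scatter, but its true size stays unread because one end of the step is a limit: the limit of > 10000 nM in this assay, at which 1 of the 3 values shown sits.

Open, going by these compounds, is how a methoxy group or an amine would read at this position. Also open, on these data alone, is how this hydroxy would read on the Z double bond of compound 1.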